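Aryl variation on the acylhydrazone arm of the shared core

The compounds below may be only part of what the source reports. "The series", "measured", "known", "first", "only" and "open" are said of these compounds alone.

Three compounds of the series carry the same core and differ only in the aryl group on the carbon with a double bond to nitrogen. Compound 1 `CN(C)CCn1cnnc1-c1cc(Oc2ccc(NC(=O)N/N=C/c3ccc(Cl)cc3Cl)cc2F)ccn1` gives 390 nM in a functional assay on HT-29 cells (Homo sapiens) for cytotoxicity, read by MTT assay, with a stated time of 72 h; on this read-out lower numbers stand for stronger inhibition and higher numbers for weaker inhibition; compound 2 `CN(C)CCn1cnnc1-c1cc(Oc2ccc(NC(=O)N/N=C/c3c(Cl)cccc3Cl)cc2F)ccn1` gives 280 nM; compound 3 `CN(C)CCn1cnnc1-c1cc(Oc2ccc(NC(=O)N/N=C/c3cccc(Br)c3)cc2F)ccn1` gives 380 nM. All three sit together: a 1.4-fold lower number from compound 1 to compound 2 (0.14 log units; within the scatter), a 1.0-fold lower number from compound 1 to compound 3 (0.01 log units; within the scatter) and a 1.4-fold higher number from compound 2 to compound 3 (0.13 log units; within the scatter), so no aryl group among them separates from the others on this read-out. Compound 3 stands within the scatter of both neighbours.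

Compound 4 `CN(C)CCn1cnnc1-c1cc(Oc2ccc(NC(=O)N/N=C/c3ccc(F)cc3Cl)cc2F)ccn1` is not yet measured. It differs from compound 3 by 2-chloro-4-fluorophenyl in place of 3-bromophenyl on a carbon with a double bond to nitrogen. For the measured compounds named here, the steps that bear on it are the exchange from compound 1 to compound 3 and from compound 2 to compound 3, both within the scatter, and the 2-chloro-4-fluorophenyl of compound 4 is nearest to the 2,4-dichlorophenyl of compound 1, whose value 390 nM matches compound 3. No step beyond the scatter is therefore expected in this assay for compound 4; the expected step is no change at the digits printed from compound 3 to compound 4 (within the scatter). The estimate for compound 4 is 380 nM, with a range from 190 nM to 760 nM.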

Compound 4, half-maximal inhibitory concentration: 510 nM
For compound 4 the middle estimate is 1.3-fold (0.13 log units) below the measured one, within the range that was stated.
By their numbers in this assay, from the lowest: compounds 2, 3, 1 and 4 (each within the scatter of the next).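

In this assay the exchange on the carbon with a double bond to nitrogen gives a 1.3-fold higher number from compound 3 to compound 4 (0.13 log units; within the scatter) and a 1.8-fold higher number from compound 2 to compound 4 (0.26 log units; within the scatter) and both steps stay within the scatter, so the 2-chloro-4-fluorophenyl group does not separate from the other aryl groups. New here is a change of one halogen alone, fluoro in place of chloro on an aromatic carbon, which gives a 1.3-fold higher number from compound 1 to compound 4 (0.12 log units; within the scatter) and also stays within the scatter. No measurement at hand bears on why these values sit together.

All four aryl groups carry only halogens, so an amine, a carboxylic acid, a methoxy group or a longer alkyl chain at this position remains an open case. Going by these compounds, whether any group here can move the number beyond the scatter also stays open.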